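Swapping Benzoyl for Cyano on the Vinyl Sulfone Chain

The source may hold more compounds than are shown below. What is called first, only, known or untested is meant among the compounds shown, and "the series" means these compounds.

Compound 2 `O=C(/C(=C\c1c(-c2ccccc2)[nH]c2ccccc12)S(=O)(=O)c1ccccc1)c1ccccc1` gives 7800 nM in a functional assay on COLO 205 cells (Homo sapiens) for inhibition, read by sulforhodamine B assay, with a stated time of 48 h (a higher number here means a weaker inhibitor of growth, a lower number a stronger inhibitor of growth), the highest of the three numbers recorded there. Its nearest neighbour is compound 3 `COc1ccc(-c2[nH]c3ccc(OC)cc3c2C=C(C#N)C#N)cc1`, which in this assay gives 291 nM, and the furthest is compound 1 `COc1ccc(-c2[nH]c3ccccc3c2/C=C(\C#N)S(=O)(=O)c2ccccc2)cc1`, which gives 254 nM; both gaps to compound 2 lie beyond the scatter, while compound 1 and compound 3 sit within the scatter of each other. For the measured compounds named here, no pair of measured compounds differs in a single place, so no measured step is available. Compound 4 `N#C/C(=C\c1c(-c2ccccc2)[nH]c2ccccc12)S(=O)(=O)c1ccccc1` differs from compound 2 in one place: cyano in place of benzoyl on a double-bonded chain carbon bound to a double-bonded chain carbon and a sulfonyl sulfur. Compound 1 carries the same cyano at the same chain carbon but also differs from compound 4 in a second place, so the two changes cannot be separated. A drop beyond the scatter is nonetheless expected, a 17-fold lower number from compound 2 to compound 4 (1.24 log units; beyond the scatter), because compound 1 gives 254 nM while carrying cyano at that chain carbon. For compound 4 the expected value in this assay is 450 nM, within a range from 150 nM to 1600 nM.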

Compound 4, concentration for 50% growth inhibition: 1400 nM
For compound 4 the middle estimate is 3.1-fold (0.49 log units) below the measured one; measured number inside the range.
By their numbers in this assay, from the lowest: compounds 1 and 3 (each within the scatter of the next); then compound 4; then compound 2.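

In this assay, the cyano-for-benzoyl swap on this chain carbon can now be read on its own, and it gives a 5.6-fold lower number from compound 2 to compound 4 (0.75 log units; beyond the scatter) with the rest of the molecule unchanged. The smaller cyano group therefore improves on benzoyl here, but the step is modest. The second step, a 5.5-fold higher number from compound 1 to compound 4 (0.74 log units; beyond the scatter), shows that hydrogen in place of methoxy on an aromatic carbon also matters, so the two changes that compound 1 carries relative to compound 2 each contribute, and cyano alone does not reach the level of compound 1.

Nothing measured here explains why either change moves the number. The compounds shown leave open how a carboxylic acid or an amide would behave on this chain carbon, and whether methoxy would give a similar step with benzoyl in place.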